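Replacing the Thiadiazole on the Sulfonamide Nitrogen of Compound 3

The source may hold more compounds than are shown below. What is called first, only, known or untested is meant among the compounds shown, and "the series" means these compounds.

Of the compounds shown here, three have been measured in an assay on cells for inhibition of sodium channel protein type 3 subunit alpha (Homo sapiens), read by electrophysiology; a higher number here means a weaker inhibitor, a lower number a stronger inhibitor. Compound 3 `O=C(NCc1ccc(OC(F)(F)F)c(Cl)c1)c1ccc(S(=O)(=O)Nc2ncns2)c(F)c1` gives 13 nM, the lowest of the three numbers. Compound 1 `O=C(NCc1ccc(C(F)(F)F)cc1)c1ccc(S(=O)(=O)Nc2nccs2)cc1` gives 147 nM, and compound 2 `O=C(COc1ccc(F)cc1)N1CCc2cc(S(=O)(=O)Nc3nccs3)ccc21` gives 2510 nM; both steps from compound 3 lie beyond the scatter, so compound 3 is the most potent inhibitor among the measured set. No pair of these compounds differs in a single place, so none of the steps between them can be assigned to one change.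

Compound 4 `O=C(NCc1ccc(OC(F)(F)F)c(Cl)c1)c1ccc(S(=O)(=O)Nc2cccnn2)c(F)c1` is a single-point variant of compound 3: pyridazin-3-yl in place of 1,2,4-thiadiazol-5-yl on a sulfonamide nitrogen. Among the measured compounds shown here, no measured pair shows the same change, so the expected size of the step rests only on the structural change itself. A modest weakening, beyond the scatter, is expected for compound 4, and the estimated step is a 3.1-fold higher number from compound 3 to compound 4 (0.49 log units; beyond the scatter). In this assay compound 4 is therefore expected to give about 40 nM, with a range from 10 nM to 200 nM.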

Compound 4, half-maximal inhibitory concentration in the sodium channel protein type 3 subunit alpha assay: 1790 nM
Estimate against measurement, compound 4: 45-fold (1.65 log units) below; the whole stated range lies below it.
By their numbers in the sodium channel protein type 3 subunit alpha assay, from the lowest: compound 3; then compound 1; then compounds 4 and 2 (each within the scatter of the next).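

Among the compounds shown here, the pair gives the first step in the set that can be assigned to a single change, and it shows that inhibition is highly sensitive to the ring on this sulfonamide nitrogen: in the sodium channel protein type 3 subunit alpha assay, pyridazin-3-yl in place of 1,2,4-thiadiazol-5-yl gives a 140-fold higher number from compound 3 to compound 4 (2.14 log units; beyond the scatter) with compound 3 at 13 nM and compound 4 at 1790 nM. In a physicochemical assay for lipophilicity (a higher number here means a more lipophilic compound, a lower number a more polar compound), compound 3 gives 2.1 and compound 4 gives 2.4; the same change gives a number 0.30 log units higher from compound 3 to compound 4 (within the scatter), so that assay does not separate the two compounds. Nothing in the data at hand accounts for the large step in inhibition.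

Still open, going by these compounds, is whether the loss is specific to pyridazin-3-yl or would also follow from other rings at this position, such as pyrimidin-2-yl or 1,3,4-thiadiazol-2-yl. Also open, on these data alone, is whether a step of this size would recur on the core of compound 1.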